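A few compounds are considered here, and "the series" means these few. Any claim that something is new, unique, unknown or untested is made for them only; others in the source may bear on it.

Measured compounds in a functional assay on G-361 cells (Homo sapiens) for antiproliferative activity, with a stated time of 72 h; a lower number here means a stronger inhibitor, a higher number a weaker inhibitor:
- compound 1 `OC[C@H]1O[C@@H](n2cnc3c(NCc4ccc(Br)cc4)ncnc32)[C@H](O)[C@@H]1O`: > 166000 nM
- compound 2 `OC[C@H]1O[C@@H](n2cnc3c(NCc4ccc(Cl)cc4Cl)ncnc32)[C@H](O)[C@@H]1O`: 128000 nM
- compound 3 `COc1cccc(CNc2ncnc3c2ncn3[C@@H]2O[C@H](CO)[C@@H](O)[C@H]2O)c1O`: 148000 nM

The figure for compound 1 in this assay is a limit of the assay and not a number; it sits at the limit of > 166000 nM in this assay, at which 1 of the 3 values shown sits. Compound 2 and compound 3 both give numbers, but the steps of an at least 1.2-fold lower number from compound 1 to compound 2 (0.11 log units; that floor lies within the scatter) and an at least 1.1-fold lower number from compound 1 to compound 3 (0.04 log units; that floor lies within the scatter) carry only floors, and those floors lie within the scatter. Between compound 2 and compound 3 the step of a 1.2-fold higher number from compound 2 to compound 3 (0.06 log units; within the scatter) is also within the scatter, so no ordering among the three is supported.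

Compound 4 `Cc1ccc(O)c(CNc2ncnc3c2ncn3[C@@H]2O[C@H](CO)[C@@H](O)[C@H]2O)c1` is not yet measured. It differs from compound 1 by 2-hydroxy-5-methylphenyl in place of 4-bromophenyl on a saturated chain carbon bound to a nitrogen on an aromatic ring. Within the data shown here, the nearest measured step is the one to compound 3, where a hydroxy-bearing aryl group likewise replaces 4-bromophenyl; that step an at least 1.1-fold lower number from compound 1 to compound 3 (0.04 log units; that floor lies within the scatter) gave no change beyond the scatter. Against that background the expectation for compound 4 in this assay is a number near the values of compound 2 and compound 3, with a fair chance that only a limit is returned again.

Compound 4 is expected at 150000 nM, within 60000 nM to 400000 nM. The expected step from compound 1 is an at least 1.1-fold lower number from compound 1 to compound 4 (0.04 log units; that floor lies within the scatter).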

Compound 4, half-maximal inhibitory concentration: > 166000 nM
Compound 4 was reported as a limit (the forecaster's own chance of this, stated with the estimate: 45%); middle value at least 1.1-fold (0.04 log units) away from the limit.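

In this assay compound 4 returns a limit of the assay and not a number, > 166000 nM. The readable steps, an at least 1.1-fold higher number from compound 3 to compound 4 (0.04 log units; that floor lies within the scatter) and an at least 1.2-fold higher number from compound 2 to compound 4 (0.11 log units; that floor lies within the scatter), carry only floors within the scatter, and the step between the two limit compounds cannot be read. Two different aryl groups at this place, 4-bromophenyl and 2-hydroxy-5-methylphenyl, now share one limit, and no change on the saturated chain carbon has yet moved a value beyond the scatter: the limit of > 166000 nM in this assay, at which 2 of the 4 values shown sit.

On these data alone, how far compound 1 and compound 4 lie from each other past that limit stays open. Also open, as far as these compounds go, is whether an amine or a carboxylic acid on the aryl ring, or a longer chain in place of the benzyl carbon, would give a value clearly separated from this range.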